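The compounds below may be only part of what the source reports. "The series", "measured", "known", "first", "only" and "open" are said of these compounds alone.

Compound 1 `CC(=O)NCc1cccc(Cn2nc(NS(=O)(=O)c3ccc(Cl)s3)c3c(C#N)cccc32)c1` and compound 2 `COc1cccc2c1c(NS(=O)(=O)c1ccc(Cl)c(Cl)c1)nn2Cc1cccc(CNC(=O)C(C)(C)O)c1` have both been measured in a physicochemical assay for lipophilicity; a higher number here means a more lipophilic compound, a lower number a more polar compound. Compound 1 gives 2.5, and compound 2 gives 5.1, the higher of the two numbers, with a gap between them that lies well beyond the usual scatter. Compound 3 `COc1cccc2c1c(NS(=O)(=O)c1ccc(C)c(F)c1)nn2Cc1cccc(CNC(=O)C(C)(C)O)c1` has not yet been measured; it differs from compound 2 in a single place: 3-fluoro-4-methylphenyl in place of 3,4-dichlorophenyl on a sulfonyl sulfur. Among the measured compounds shown here, no measured pair shows this exchange on its own. The step from compound 2 to compound 3 in this assay is expected to be a moderate fall, a number 0.70 log units lower from compound 2 to compound 3 (beyond the scatter), larger than the scatter. Compound 3 is accordingly expected to come out near 4.4, somewhere between 3.9 and 4.9.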

Compound 3, distribution coefficient: 4.5
For compound 3 the middle estimate is 0.10 log units below the measured one, within the range that was stated.
By their numbers in this assay, from the lowest: compound 1; then compound 3; then compound 2.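

In this assay, putting 3-fluoro-4-methylphenyl in place of 3,4-dichlorophenyl on the sulfonyl sulfur gives a number 0.60 log units lower from compound 2 to compound 3 (beyond the scatter). Both groups have 8 heavy atoms and one six-membered aromatic ring of carbon only, so the number shifts at this position even though those counts stay the same. Nothing measured here gives a reason for this shift. The compounds shown do not separate the part played by the fluorine from that of the methyl. They also leave open what a phenyl ring carrying an amine or a carboxylic acid would give at this position.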